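Inactive lignan rhamnosides: a core stereochemistry inversion

This account rests on a few compounds, and the source may have more. Where it says the series, first, only, none or still open, it means among the compounds named here.

The series consists of glycosylated lignans tested in a functional assay on HCT-15 cells (Homo sapiens) for cytotoxicity, read by sulforhodamine B assay; a higher number here means a weaker inhibitor, a lower number a stronger inhibitor. Compound 1 `COc1cc([C@H]2Oc3c(OC)cc(CCCO)cc3[C@@H]2CO[C@@H]2O[C@@H](C)[C@H](O)[C@@H](O)[C@H]2O)cc(OC)c1O` gives only a limit, > 10000 nM, in this assay. Compound 2 `COc1cc(C[C@H]2CO[C@@H](c3cc(OC)c(O)c(OC)c3)[C@H]2CO[C@@H]2O[C@@H](C)[C@H](O)[C@@H](O)[C@H]2O)cc(OC)c1O` likewise reaches only the limit > 10000 nM in this assay. Compound 3 `COc1cc([C@H]2c3c(cc(OC)c(O)c3OC)C[C@@H](CO)[C@@H]2CO[C@@H]2O[C@@H](C)[C@H](O)[C@@H](O)[C@H]2O)cc(OC)c1O` also returns a limit, > 10000 nM, in this assay. Compound 1 therefore stands with the others at the limit of > 10000 nM in this assay, at which 3 of the 3 values shown sit, so no order among compound 1, compound 2 and compound 3 can be read from these numbers.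

The step from compound 1 to compound 4 `COc1cc([C@@H]2Oc3c(OC)cc(CCCO)cc3[C@H]2CO[C@@H]2O[C@@H](C)[C@H](O)[C@@H](O)[C@H]2O)cc(OC)c1O` changes no atom or bond: the two compounds have the same atoms and bonds and differ only in configuration as drawn: 2 of 7 stereo elements differ; a stereocentre at a saturated ring carbon is drawn S in compound 1 and R in compound 4; a stereocentre at a saturated ring carbon is drawn R in compound 1 and S in compound 4. Among the compounds with values here, no step between measured compounds exists for comparison here, and the only information is that the whole set sits at the limit of this assay.

Given that compound 1 shows > 10000 nM, compound 4 is expected to remain at or beyond the same limit, with the expected change a step that the limit leaves unreadable from compound 1 to compound 4 amounting to nothing beyond the scatter. The estimate for compound 4 in this assay is 20000 nM, with a range from 5000 nM to 100000 nM.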

Compound 4, half-maximal inhibitory concentration: > 10000 nM
Compound 4 ended at the assay's limit (the forecaster's own chance of this, stated with the estimate: 85%); the middle value is on the limit's open side.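

Within the data shown here, compound 1 and compound 4 both stand at a limit, so no step between them can be read: the limit of > 10000 nM in this assay, at which 4 of the 4 values shown sit.

The compounds shown leave open whether the drawn configuration, or any other difference among them, alters cytotoxicity at concentrations beyond that limit.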